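This account rests on a few compounds, and the source may have more. Where it says the series, first, only, none or still open, it means among the compounds named here.

Measured so far in a functional assay on the whole organism (6C3HED cells, Mus musculus) for inhibition, at a dose of 300 mg/kg by the oral route; a lower number here means less inhibition, a higher number more inhibition at the dose given (going by the name of the read-out):

- compound 1 `CC(C)c1ccc(S(=O)(=O)NC(=O)Nc2ccc(Cl)cc2)s1` gives 63%
- compound 2 `CCCOc1ccc(S(=O)(=O)NC(=O)Nc2ccc(Cl)cc2)s1` gives 63%
- compound 3 `CCc1ccc(S(=O)(=O)NC(=O)Nc2ccc(Cl)cc2)o1` gives 80%

Compound 3 stands highest of the three numbers; compound 1 and compound 2 both lie lower, by a gap beyond the usual scatter. Within the data shown here, the only step with a single change, no change at the digits printed from compound 1 to compound 2 (within the scatter), shows that swapping one side group for another on the ring of compound 1 leaves the read-out where it was.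

Compound 4 `Cc1cc(S(=O)(=O)NC(=O)Nc2ccc(Cl)cc2)sc1C` has not been measured. It differs from compound 3 in the group on the sulfonyl sulfur: 4,5-dimethylthiophen-2-yl in place of 5-ethylfuran-2-yl on a sulfonyl sulfur. Among the measured compounds shown here, no measured step swaps a ring of one kind for a ring of the other, so nothing bears on this change directly. What the data do show is that compound 1 and compound 2, whose ring holds sulfur like the group that enters, both sit well below compound 3, while a change of side group on that ring made no difference. It therefore seems reasonable to expect compound 4 to come out below compound 3, closer to where compound 1 and compound 2 stand, an expected step of a number 15 percentage points lower from compound 3 to compound 4 (beyond the scatter). For compound 4 the estimate is 65%, with a range from 48% to 82%.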

Compound 4, a percentage reported as inhibition, in the whole organism at one dose (the size of the read-out at that dose, not a potency): 73%
The estimate for compound 4 lay 8 percentage points below the measured number; the measured number falls inside the stated range.
By their numbers in this assay, from the lowest: compounds 1, 2, 4 and 3 (each within the scatter of the next, the first and the last beyond it).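

In this assay, putting 4,5-dimethylthiophen-2-yl in place of 5-ethylfuran-2-yl on a sulfonyl sulfur gives a number 7 percentage points lower from compound 3 to compound 4 (within the scatter), so this exchange of one ring and its side groups for another does not move the read-out beyond the usual spread of repeated measurements. The earlier step changed only a side group on a ring that stayed in place, whereas this one shows that a ring holding sulfur can replace a ring holding oxygen at this position, at least when both groups have 7 heavy atoms and one five-membered aromatic ring with 1 hetero atom. Nothing available explains why the read-out stays within that spread.

The step changes the ring's hetero atom and its side groups together, so the compounds shown leave open what each change does alone, a question that 5-ethylthiophen-2-yl, with the ethyl group kept and only oxygen exchanged for sulfur, would address directly. They also leave open how this position responds to a group of a different kind on the ring, such as an amine, a carboxylic acid or a longer chain.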